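Swapping the aryl group on a thiazole hydrazone

The source may hold more compounds than are shown below. What is called first, only, known or untested is meant among the compounds shown, and "the series" means these compounds.

Measured so far:
Compound 1 `COc1cc(/C=N/Nc2nc(-c3ccc(Br)cc3)cs2)cc(Br)c1OC`: 52300 nM
Compound 2 `Fc1ccc(/C=N/Nc2nc(-c3cc(C(F)(F)F)cc(C(F)(F)F)c3)cs2)cc1F`: 6230 nM

In a functional assay on A549 cells (Homo sapiens) for inhibition, read by MTT assay, with a stated time of 48 h (on this read-out higher numbers stand for weaker inhibition and lower numbers for stronger inhibition), compound 1 gives the higher of the two numbers; compound 2 gives a number that lies beyond the scatter below it. Compound 3 `COc1ccccc1-c1csc(N/N=C/c2cc(Br)c(OC)c(OC)c2)n1` differs from compound 1 by 2-methoxyphenyl in place of 4-bromophenyl on an aromatic carbon. Within the data shown here, no measured pair shows this change, so no reading of its effect is available. Compound 3 is estimated at 45000 nM, within 15000 nM to 150000 nM, and the expected step of a 1.2-fold lower number from compound 1 to compound 3 (0.07 log units; within the scatter) is not expected to exceed the scatter.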

Compound 3, half-maximal inhibitory concentration: 94900 nM
Compound 3: the middle estimate sits 2.1-fold (0.32 log units) below what was measured; the range from low to high includes it.
By their numbers in this assay, from the lowest: compound 2; then compounds 1 and 3 (each within the scatter of the next).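

Among these compounds, this is the first direct reading at this position, on the aromatic carbon next to the ring nitrogen. In this assay, 2-methoxyphenyl in place of 4-bromophenyl gives a 1.8-fold higher number from compound 1 to compound 3 (0.26 log units; within the scatter), so the two aryl groups cannot be told apart on this read-out, even though they differ in the place and kind of their substituent. No measurement on hand accounts for this result. Still open, on these data alone, is how an aryl group carrying an amine or a carboxylic acid would read at this position, and whether this exchange would read the same on another aldehyde-derived side of the molecule.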